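Adding 2-methylphenyl to compound 2

The source may hold more compounds than are shown below. What is called first, only, known or untested is meant among the compounds shown, and "the series" means these compounds.

Compound 1 `Nc1ncn(Cc2c(Cl)cccc2Cl)c2ncnc1-2` gives 17100 nM
Compound 2 `Nc1ncn(Cc2c(Cl)cncc2Cl)c2ncnc1-2` gives 27900 nM

In an ADME assay on the whole organism (Mus musculus, strain C57BL/6) for pharmacokinetics, read by LC-MS, with a stated time of 24 h, at a dose of 10 mg/kg by the oral route (on this read-out higher numbers stand for higher exposure at the dose given and lower numbers for lower exposure), compound 2 and compound 1 lie within the usual scatter of each other, so neither can be ranked above the other. Among the compounds with values here, compound 3 `Cc1ccccc1-c1nc2c(N)ncn(Cc3c(Cl)cncc3Cl)c-2n1` differs from compound 2 by 2-methylphenyl in place of hydrogen on an aromatic carbon and no measured pair shows what such a change does. A fall beyond the scatter is therefore only a rough expectation (a 4.7-fold lower number from compound 2 to compound 3 (0.67 log units; beyond the scatter)). In this assay the expected value for compound 3 is 6000 nM (range 1500 nM to 20000 nM).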

Compound 3, maximal plasma concentration: 44.1 nM
Compound 3: the middle estimate sits 140-fold (2.13 log units) above what was measured, and the stated range ends above it.
By their numbers in this assay, from the lowest: compound 3; then compounds 1 and 2 (each within the scatter of the next).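

In this assay the aromatic carbon between two ring nitrogen atoms proves highly sensitive: 2-methylphenyl in place of hydrogen gives a 630-fold lower number from compound 2 to compound 3 (2.80 log units; beyond the scatter) and so a large loss of exposure. Compound 1 and compound 2 both carry hydrogen on this carbon, so they could not show this. Nothing measured here accounts for the fall. As far as these compounds go, it remains open whether any group on this carbon lowers exposure so far, or mainly this one. A methyl group or an amine in the same place would help separate those two readings.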